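Urea Aryl Swap on a Pyrimidine Anilide Series

The source may hold more compounds than are shown below. What is called first, only, known or untested is meant among the compounds shown, and "the series" means these compounds.

The measured compounds are:
compound 1, `COc1cc(NC(=O)Nc2cc(Nc3ccc(OC)c(C)c3)ncn2)cc(OC)c1`, 19.7%;
compound 2, `COc1cc(NC(=O)Nc2cc(Nc3ccc(C)c(F)c3)ncn2)cc(OC)c1`, 38%;
compound 3, `CC(C)(C)c1ccc(Nc2cc(NC(=O)Nc3c(Cl)cccc3Cl)ncn2)cc1`, 71.3%.

In a functional assay on NCI-H1581 cells (Homo sapiens) for inhibition, read by MTT assay, with a stated time of 48 h, tested at 10 uM (a lower number here means less inhibition, a higher number more inhibition at the concentration tested (going by the name of the read-out)), compound 3 stands highest of the three numbers: compound 2 is the nearest to it, and compound 1 the furthest, both separated from compound 3 by more than the scatter. For the measured compounds named here, the one measured step within this set, a number 18.3 percentage points higher from compound 1 to compound 2 (beyond the scatter), alters the aryl group on the aromatic-ring nitrogen, not the urea end.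

Compound 4, `COc1cc(NC(=O)Nc2cc(Nc3ccc(C(C)(C)C)cc3)ncn2)cc(OC)c1`, is derived from compound 3 by the change (3,5-dimethoxyphenyl in place of 2,6-dichlorophenyl on an amide-type nitrogen). Going by the values given here, no measured step touches that position, so nothing directly anchors the expected size of the change. What can be said is that compound 1 and compound 2 both carry a 3,5-dimethoxyphenyl on the amide-type nitrogen and both give lower numbers than compound 3, though they also differ from compound 3 at the other aryl group, so the two effects cannot be separated.

The estimate for compound 4 is therefore a downward step, a number 26.3 percentage points lower from compound 3 to compound 4 (beyond the scatter), with wide uncertainty. Compound 4 is expected to give about 45%, somewhere between 20% and 72%.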

Compound 4, a percentage reported as inhibition, at one concentration (the size of the read-out at that concentration, not a potency): 38.7%
For compound 4 the middle estimate is 6.3 percentage points above the measured one, and the stated range covers the measured number.
By their numbers in this assay, from the lowest: compound 1; then compounds 2 and 4 (each within the scatter of the next); then compound 3.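

In this assay, for the compounds shown here, a number 32.6 percentage points lower from compound 3 to compound 4 (beyond the scatter), and this is the first step that isolates the amide-type nitrogen: 3,5-dimethoxyphenyl replaces 2,6-dichlorophenyl while the 4-(tert-butyl)phenyl at the other end stays fixed, so the change at the urea end can now be read apart from the other aryl group. With 3,5-dimethoxyphenyl held in place, 4-(tert-butyl)phenyl in place of 3-fluoro-4-methylphenyl gives a number 0.7 percentage points higher from compound 2 to compound 4 (within the scatter), whereas 4-(tert-butyl)phenyl in place of 4-methoxy-3-methylphenyl gives a number 19 percentage points higher from compound 1 to compound 4 (beyond the scatter), so among these three compounds only compound 1 stands apart. Nothing available explains the size of any of these steps.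

Going by these compounds alone, only one pair isolates the change at the amide-type nitrogen, so it remains open whether 2,6-dichlorophenyl would give a similar gain with 3-fluoro-4-methylphenyl or 4-methoxy-3-methylphenyl at the other end. The compounds shown also cannot tell whether the gap follows the two chlorine atoms or the two methoxy groups, a question that a plain phenyl or a 2,6-dimethylphenyl on that nitrogen would address.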